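The source may report more compounds than this note shows. Statements on the series, on what has been measured and on what is new or still open speak of the compounds shown alone.

Measured so far in an ADME assay on Vero cells (Chlorocebus sabaeus) for cytotoxicity, read by MTT assay, with a stated time of 72 h; a higher number here means that more compound is tolerated, a lower number that less compound is tolerated:
compound 1, `CCOC(=O)c1c(-c2ccc(OC)cc2)oc2ccc(OCCCCCCN3C(=O)/C(=N\OC)c4ccccc43)cc12`, gives 32 ug/mL
compound 2, `CCO/N=C1\C(=O)N(CCCCOc2ccc3oc(-c4ccc(OC)cc4)c(C(=O)OCC)c3c2)c2ccccc21`, gives 64 ug/mL
compound 3, `CCO/N=C1\C(=O)N(CCCCCCOc2ccc3oc(-c4ccc(OC)cc4)c(C(=O)OCC)c3c2)c2ccccc21`, gives 16 ug/mL

Compound 4, `CCOC(=O)c1c(-c2ccc(OC)cc2)oc2ccc(OCCCCN3C(=O)/C(=N\OC)c4ccccc43)cc12`, is not yet measured in this assay. Compound 4 arises from compound 2 by the change (hydrogen in place of methyl on a saturated chain carbon bound to an oxygen on an unsaturated carbon). The same change occurs once among the measured compounds: compound 1 arises from compound 3 by hydrogen in place of methyl on a saturated chain carbon bound to an oxygen on an unsaturated carbon, and that step gave a 2.0-fold higher number from compound 3 to compound 1 (0.30 log units; within the scatter). The cores of compound 2 and compound 3 differ, but this difference is not broken down here; their values show compound 2 tolerated at the higher number, a gap beyond the scatter. Since the earlier step stayed within the scatter, the change is expected to be roughly neutral, and the step is expected to be a 1.3-fold higher number from compound 2 to compound 4 (0.10 log units; within the scatter), resting on a 2.0-fold higher number from compound 3 to compound 1 (0.30 log units; within the scatter). Compound 4 is therefore estimated at 80 ug/mL, expected to fall between 32 ug/mL and 160 ug/mL.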

Compound 4, half-maximal cytotoxic concentration: 32 ug/mL
Compound 4: middle estimate off by 2.5-fold (0.40 log units), on the high side, within the range that was stated.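

In this assay, going from ethoxy to methoxy gives a 2.0-fold lower number from compound 2 to compound 4 (0.30 log units; within the scatter). Set beside the earlier step on the other core, it runs the opposite way, and the two steps differ by more than their scatter: the same change on two cores in this assay, a 2.0-fold higher number (0.30 log units; within the scatter) from compound 3 to compound 1 and a 2.0-fold lower number (0.30 log units; within the scatter) from compound 2 to compound 4, 4.0-fold (0.60 log units) apart, beyond the scatter of two such steps. The change therefore cannot be carried from one core to the other as a fixed step, though each step alone remains within the scatter, and two pairs neither show what in the cores sets the difference nor establish a rule for the series.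

As far as these compounds go, whether a propoxy group in place of ethoxy would follow either step remains open. So does the outcome of the same change on a third core, such as one with a longer chain or an amine.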